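From 1-(pyridin-2-yl)ethyl to 4-isopropyl-1,3-thiazol-2-yl

The compounds below may be only part of what the source reports. "The series", "measured", "known", "first", "only" and "open" are said of these compounds alone.

- Compound 1 `CC(C)(C)Sc1c(CC(C)(C)C(=O)O)n(Cc2ccc(Cl)cc2)c2ccc(OCc3ccc4cc(F)ccc4n3)cc12` (880 nM)
- Compound 2 `C[C@H](COc1ccc2c(c1)c(SC(C)(C)C)c(CC(C)(C)C(=O)O)n2Cc1ccc(Cl)cc1)c1ccccn1` (470 nM)
- Compound 3 `CC(C)c1csc(COc2ccc3c(c2)c(SC(C)(C)C)c(CC(C)(C)C(=O)O)n3Cc2ccc(Cl)cc2)n1` (not yet measured)

Both numbers come from a functional assay (blood) for inhibition, with Homo sapiens as the target (a higher number here means a weaker inhibitor, a lower number a stronger inhibitor), and they sit within the usual scatter of each other, so compound 2 cannot be ranked against compound 1. The change now in view replaces one group on a saturated chain carbon bound to an oxygen on an aromatic ring (4-isopropyl-1,3-thiazol-2-yl in place of 1-(pyridin-2-yl)ethyl on a saturated chain carbon bound to an oxygen on an aromatic ring) and puts 4-isopropyl-1,3-thiazol-2-yl in place of 1-(pyridin-2-yl)ethyl. For the measured compounds named here, only one measured step bears on this place, where 1-(pyridin-2-yl)ethyl took the place of 6-fluoroquinolin-2-yl (a 1.9-fold lower number from compound 1 to compound 2 (0.27 log units; within the scatter)). Going by the values given here, that step did not leave the scatter, yet a single step is thin evidence, and no measured compound carries the incoming group. No step beyond the scatter is therefore expected in this assay and no firm direction can be given. The estimate amounts to a 1.2-fold higher number from compound 2 to compound 3 (0.07 log units; within the scatter) as the expected step. Compound 3 is expected near 550 nM with an estimated range from 220 nM to 1300 nM for its measured value.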

Compound 3, half-maximal inhibitory concentration: > 3000 nM
Compound 3: only a limit was reported; the forecaster's own chance of this, stated with the estimate: 3%; middle value at least 5.4-fold (0.73 log units) from the limit.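

In this assay the reading for compound 3 is a limit and not a number: the limit of > 3000 nM in this assay, at which 1 of the 3 values shown sits.

Until now, this place on a saturated chain carbon bound to an oxygen on an aromatic ring had shown a single step within the scatter, so 6-fluoroquinolin-2-yl and 1-(pyridin-2-yl)ethyl could not be told apart. The new group shows that a change here can move the number well beyond the scatter, with an at least 6.3-fold higher number from compound 2 to compound 3 (0.80 log units; beyond the scatter) and an at least 3.4-fold higher number from compound 1 to compound 3 (0.53 log units; beyond the scatter); it gives a weaker inhibitor than either earlier group, even though 4-isopropyl-1,3-thiazol-2-yl and 1-(pyridin-2-yl)ethyl have the same count of heavy atoms and each brings an aromatic ring.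

The compounds shown cannot say whether the loss belongs to the five-membered ring with its sulfur or to the isopropyl on it, a question that a plain 1,3-thiazol-2-yl or a 4-methyl-1,3-thiazol-2-yl would address. From the compounds shown here alone, how far compound 3 really lies past its limit also stays open, as does whether the defined stereocentre of 1-(pyridin-2-yl)ethyl plays any part in the number of compound 2.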